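Sulfonyl aryl change from compound 2 to compound 3

This account rests on a few compounds, and the source may have more. Where it says the series, first, only, none or still open, it means among the compounds named here.

In an ADME assay on HCT-116 cells (Homo sapiens) for cytotoxicity, read by CellTiter-Glo, with a stated time of 72 h (a lower number here means a stronger inhibitor, a higher number a weaker inhibitor), compound 1 (`CC1CCN(C2CCN(S(=O)(=O)c3cccnc3)CC2)CC1`) gives > 10000 nM, which is a limit. Compound 2 (`CC1CCN(C2CCN(S(=O)(=O)c3cccc(Br)c3)CC2)CC1`) gives > 5000 nM, also a limit, so compound 2 has no numerical value. The change to compound 3 (`CC1CCN(C2CCN(S(=O)(=O)c3cc(Cl)cc(Cl)c3)CC2)CC1`) is 3,5-dichlorophenyl in place of 3-bromophenyl on a sulfonyl sulfur. Going by the values given here, the only measured step, a step that the two limits leave unreadable from compound 1 to compound 2, bears on this aryl position but gives no usable size or direction. No step beyond the scatter is therefore expected in this assay. The estimated step is a step that the limit leaves unreadable from compound 2 to compound 3. Compound 3 is expected at 6000 nM, with an estimated range of 2000 nM to 15000 nM.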

Compound 3, half-maximal inhibitory concentration: > 5000 nM
Compound 3: no number, only a limit; the forecaster's own chance of this, stated with the estimate: 65%; the middle value is on the limit's open side.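

Going by these compounds alone, compound 1, compound 2 and compound 3 each give only a limit in this assay, so no step among them can be read. The compounds shown leave open how the sulfonyl aryl group affects the half-maximal inhibitory concentration.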